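Swapping Phenyl for Carboxymethyl on an Aromatic Nitrogen

The source may report more compounds than this note shows. Statements on the series, on what has been measured and on what is new or still open speak of the compounds shown alone.

Compound 1 (`Cc1nn(-c2ccccc2)c(S)c1C(=O)c1ccccc1`) -0.3
Compound 2 (`Cc1cc(SSc2cc(C)nn2-c2ccccc2)n(-c2ccccc2)n1`) 3.2
Compound 3 (`Cc1cc(COc2cc(C)nn2-c2ccccc2)n(-c2ccccc2)n1`) 2.2

The three compounds are spread widely in a physicochemical assay for lipophilicity, at pH 7.4, tested at 10 mM (on this read-out higher numbers stand for higher lipophilicity and lower numbers for lower lipophilicity), and their values span much of the scale seen here. Compound 3 at 2.2 is the second highest of the three. It sits under compound 2 and over compound 1, and both gaps lie beyond the usual scatter. No two of these compounds differ in one place only, so no measured step is available as a guide.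

Compound 4 (`Cc1cc(OCc2cc(C)nn2-c2ccccc2)n(CC(=O)O)n1`) has not yet been measured. Compared with compound 3, it carries carboxymethyl in place of phenyl on an aromatic nitrogen of a five-membered aromatic ring with 2 nitrogen. Going by the values given here, no measured compound carries carboxymethyl, so the size of the change remains uncertain. A large fall in this assay is nevertheless expected, well beyond the scatter, and compound 1 at -0.3 serves as a rough guide to how low the number may go. The estimated change is a number 3.00 log units lower from compound 3 to compound 4 (beyond the scatter) and would be a large one. Compound 4 is expected at -0.8 within an estimated range from -1.6 to 0.1 on this scale.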

Compound 4, distribution coefficient: 1.2
For compound 4 the middle estimate is 2.00 log units below the measured one; measured number outside the range, above it.
By their numbers in this assay, from the lowest: compound 1; then compound 4; then compound 3; then compound 2.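

Going by these compounds alone, compound 4 gives the first measured step at this position on an aromatic nitrogen, and in this assay carboxymethyl in place of phenyl produces a step of a number 1.00 log units lower from compound 3 to compound 4 (beyond the scatter) that counts as modest in size. The position therefore responds to this swap, which removes a six-membered aromatic ring of carbon only and brings in one hydrogen-bond donor and one hydrogen-bond acceptor, but this single pair cannot show which of those differences sets the size of the step. No available evidence bears on why the step has this size.

The compounds shown leave open how the number in this assay would shift with other groups at this position, such as an aminoethyl group, the methyl ester of carboxymethyl, or a longer chain ending in a carboxylic acid. They also leave open whether a plain methyl group at the same aromatic nitrogen would give a step closer to that of carboxymethyl or would leave the number nearer that of phenyl.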